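Methoxy for Bromo on the Triazole-Linked Phenyl

A few compounds are considered here, and "the series" means these few. Any claim that something is new, unique, unknown or untested is made for them only; others in the source may bear on it.

Compound 1 `C=C1C[C@]23C[C@@]1(O)CC[C@H]2c1ccc(OS(=O)(=O)c2ccc(C)cc2)c(C)c1[C@@H]3Cn1cc(-c2ccc(Cl)cc2)nn1` gives > 20000 nM in a functional assay on HL-60 cells (Homo sapiens) for cytotoxicity, read by MTT assay, with a stated time of 4 days (on this read-out higher numbers stand for weaker inhibition and lower numbers for stronger inhibition), which is a limit of the assay and not a number.
Compound 2 `C=C1C[C@]23C[C@@]1(O)CC[C@H]2c1ccc(OS(=O)(=O)c2ccc(C)cc2)c(C)c1[C@@H]3Cn1cc(-c2ccc(Br)cc2)nn1` gives > 20000 nM in this assay, likewise a limit.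

Among the measured compounds shown here, compound 2 therefore stands at the limit of this assay, as does the only other measured compound; the two values sit at the limit of > 20000 nM in this assay, at which 2 of the 2 values shown sit. For the measured compounds named here, the one measured step, a step that the two limits leave unreadable from compound 1 to compound 2, cannot be read because both ends are limits. Compound 3 `C=C1C[C@]23C[C@@]1(O)CC[C@H]2c1ccc(OS(=O)(=O)c2ccc(C)cc2)c(C)c1[C@@H]3Cn1cc(-c2ccc(OC)cc2)nn1` differs from compound 2 by methoxy in place of bromo on an aromatic carbon. Going by the values given here, no measured step bears on this change in a readable way, so no direction or size of step in this assay can be inferred, and the expectation for compound 3 is simply that it remains at the limit: the step that the limit leaves unreadable from compound 2 to compound 3 is expected to be nothing beyond the scatter. Compound 3 is estimated at 30000 nM, within 10000 nM to 100000 nM.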

Compound 3, half-maximal inhibitory concentration: > 20000 nM
Compound 3 was reported as a limit (the forecaster's own chance of this, stated with the estimate: 80%); the middle value is on the limit's open side.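

No step among compound 1, compound 2 and compound 3 can be read, because all three values are limits of this assay and not numbers: the limit of > 20000 nM in this assay, at which 3 of the 3 values shown sit.

The compounds shown leave open what difference, if any, chloro, bromo and methoxy make to cytotoxicity on these cells.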